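One Flipped Stereocentre in a Soluble Amide

The source may report more compounds than this note shows. Statements on the series, on what has been measured and on what is new or still open speak of the compounds shown alone.

The shared core of these compounds carries an amide, and the group on its carbonyl carbon is what varies. In a physicochemical assay for solubility, read by HPLC, using the shake flask method, in phosphate buffer, with a stated time of 2 h, at pH 6.5 (on this read-out higher numbers stand for higher solubility and lower numbers for lower solubility), compound 1 `NC(=O)c1ccc(-c2cnc(N)c(-c3ccc(C(F)(F)F)cc3)n2)cc1` gives < 5000 nM, which is a limit of the assay and not a number. Among the compounds with values here, compound 2 `Nc1ncc(-c2ccc(C(=O)N3CC[C@@H](O)C3)cc2)nc1-c1ccc(C(F)(F)F)cc1` gives 90000 nM, the only true number so far.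

Within the data shown here, the one measured step, an at least 18-fold higher number from compound 1 to compound 2 (1.25 log units; beyond the scatter), is large and beyond the scatter. It puts 3-hydroxypyrrolidin-1-yl in place of amino on a carbonyl carbon, so a whole group changes.

Compound 3 `Nc1ncc(-c2ccc(C(=O)N3CC[C@H](O)C3)cc2)nc1-c1ccc(C(F)(F)F)cc1` is a much smaller departure from compound 2: the two compounds have the same atoms and bonds and differ only in configuration as drawn: 1 of 1 stereo elements differ; a stereocentre at a saturated ring carbon is drawn R in compound 2 and S in compound 3. Nothing leaves and nothing enters. Among the measured compounds shown here, no measured step tests a change of configuration alone, so the earlier step offers no size or direction to carry over.

The best anchor is therefore compound 2 at 90000 nM. In this assay, the expected result is no change at the digits printed from compound 2 to compound 3 (within the scatter), meaning no shift beyond the scatter in either direction. For compound 3 the estimated value is 90000 nM, with an expected range from 45000 nM to 180000 nM.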

Compound 3, solubility: 68000 nM
The estimate for compound 3 lay 1.3-fold (0.12 log units) above the measured number; the range from low to high includes it.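

Turning the stereocentre from R to S gives a 1.3-fold lower number from compound 2 to compound 3 (0.12 log units; within the scatter), so in this assay the drawn configuration of this saturated ring carbon makes no difference that can be told from the usual scatter, and this is the first direct test of that change alone: the fact that compounds 2 and 3 differ only in the configuration as drawn

The large gain seen earlier with the 3-hydroxypyrrolidin-1-yl group also appears with the other drawn form, as an at least 13-fold higher number from compound 1 to compound 3 (1.13 log units; beyond the scatter). Compound 1 gives < 5000 nM, which is a limit of the assay and not a number, so the true size of both large steps stays unknown: the limit of < 5000 nM in this assay, at which 1 of the 3 values shown sits.

From the compounds shown here alone, it remains open how much of the large step belongs to the hydroxyl group and how much to the ring, a question that a plain pyrrolidin-1-yl group on the same carbonyl carbon would help to separate. Going by these compounds, it also remains open whether configuration would count for as little with a different group on that ring carbon, such as an amine or a carboxylic acid, or in any other kind of measurement.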